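A Second Methyl on the Amine Nitrogen

The source may hold more compounds than are shown below. What is called first, only, known or untested is meant among the compounds shown, and "the series" means these compounds.

For the measured compounds named here, in a functional assay on HCT-8 cells (Homo sapiens) for antiproliferative activity, read by MTT assay, with a stated time of 48 h (on this read-out higher numbers stand for weaker inhibition and lower numbers for stronger inhibition), compound 1 (`COc1ccc(C(=O)c2ccc(OC)c3c2OC(C)(C)C=C3)c(NC(=O)CN)c1`) gives (370 nM) and compound 2 (`CNCC(=O)Nc1cc(OC)ccc1C(=O)c1ccc(OC)c2c1OC(C)(C)C=C2`) gives (740 nM), so compound 2 stands within the scatter of its only measured neighbour. Compound 3 (`COc1ccc(C(=O)c2ccc(OC)c3c2OC(C)(C)C=C3)c(NC(=O)CN(C)C)c1`) differs from compound 2 by one change (methyl in place of hydrogen on an amine nitrogen): methyl in place of hydrogen on an amine nitrogen. The same replacement has been measured once, and that step (a 2.0-fold higher number from compound 1 to compound 2 (0.30 log units; within the scatter)) stayed within the scatter. A similarly small move toward a higher number is therefore expected in this assay, possibly none beyond the scatter. The expected step is small (a 1.4-fold higher number from compound 2 to compound 3 (0.13 log units; within the scatter)). The estimated value for compound 3 is 1000 nM (expected range from 400 nM to 2500 nM).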

Compound 3, half-maximal inhibitory concentration: 1590 nM
The estimate for compound 3 lay 1.6-fold (0.20 log units) below the measured number, and the stated range covers the measured number.
By their numbers in this assay, from the lowest: compounds 1 and 2 (each within the scatter of the next); then compound 3.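

In this assay, the second methyl on the amine nitrogen moves the number beyond the scatter, which the first methyl did not do (a 2.1-fold higher number from compound 2 to compound 3 (0.33 log units; beyond the scatter)). Read as a whole, replacing amino with dimethylamino on this saturated chain carbon gives a modest loss (a 4.3-fold higher number from compound 1 to compound 3 (0.63 log units; beyond the scatter)), so this nitrogen is sensitive to full methylation. Nothing measured here accounts for this rise.

The compounds shown leave open how an ethyl group on this nitrogen, or a pyrrolidine in place of the dimethylamino group, would read. From the compounds shown here alone, a longer chain between the carbonyl and the amine also remains open.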